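The source may report more compounds than this note shows. Statements on the series, on what has been measured and on what is new or still open speak of the compounds shown alone.

Compound 3 `COc1nc(N)nc2c1c(-c1ccccc1)cn2[C@@H]1O[C@H](CO)[C@@H](O)[C@H]1O` is the point of departure. In a functional assay on HeLa S3 cells (Homo sapiens) for antiproliferative activity, read by XTT assay, with a stated time of 72 h (a lower number here means a stronger inhibitor, a higher number a weaker inhibitor), compound 3 gives > 20000 nM, which is a limit of the assay rather than a number, the one described as the limit of > 20000 nM in this assay, at which 1 of the 3 values shown sits. Compound 1 `CN(C)c1ncnc2c1c(-c1ccsc1)cn2[C@@H]1O[C@H](CO)[C@@H](O)[C@H]1O` carries a thiophen-3-yl group on the same kind of carbon of its core. In this assay compound 1 gives > 15000 nM, again a limit of the assay, described as the limit of > 15000 nM in this assay, at which 1 of the 3 values shown sits. Compound 2 `C#Cc1cn([C@@H]2O[C@H](CO)[C@@H](O)[C@H]2O)c2ncnc(N(C)C)c12` differs from compound 1 in one place, and in this assay compound 2 gives 810 nM. Among the measured compounds shown here, the only measured step, an at least 18-fold lower number from compound 1 to compound 2 (1.26 log units; beyond the scatter), concerns an ethynyl entering for a thiophen-3-yl, not one aromatic ring replacing another, so it does not bear directly on the present change. Compound 4 `COc1nc(N)nc2c1c(-c1cccs1)cn2[C@@H]1O[C@H](CO)[C@@H](O)[C@H]1O` is not yet measured. The change is thiophen-2-yl in place of phenyl on an aromatic carbon. Since compound 3 stands at > 20000 nM, compound 4 is expected to remain at a limit as well. The step is expected to be a number no higher from compound 3 to compound 4 (the limit leaves the size open), within the scatter. The estimate for compound 4 is 20000 nM, between 7000 nM and 60000 nM.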

Compound 4, half-maximal inhibitory concentration: > 20000 nM
Compound 4: only a limit was reported; the forecaster's own chance of this, stated with the estimate: 75%; the middle value sits exactly at the limit.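

In this assay compound 4 gives > 20000 nM, which is a limit of the assay. Compound 3 gives > 20000 nM, also a limit, so the step between compound 3 and compound 4 cannot be read. The compounds shown leave open whether thiophen-2-yl and phenyl differ at all on this core in this assay.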